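Fluoro for Chloro on the Benzyl Group of Compound 2

This account rests on a few compounds, and the source may have more. Where it says the series, first, only, none or still open, it means among the compounds named here.

In a functional assay on HCT-116 cells (Homo sapiens) for inhibition, read by MTT assay, with a stated time of 48 h (on this read-out higher numbers stand for weaker inhibition and lower numbers for stronger inhibition), compound 1 `COc1ccc(C/N=C2\NC(=O)/C(=C3\CCNC(=O)c4[nH]ccc43)S2)cc1` gives 19400 nM and compound 3 `Cc1ccc(C/N=C2\NC(=O)/C(=C3\CCNC(=O)c4[nH]ccc43)S2)cc1` gives 4760 nM. Compound 2 `O=C1N/C(=N\Cc2ccc(Cl)cc2)S/C1=C1/CCNC(=O)c2[nH]ccc21` reaches only a limit of this assay, > 100000 nM. Compound 2 therefore stands at the weak end of the three measured compounds, sitting at the limit of > 100000 nM in this assay, at which 1 of the 3 values shown sits. The measured steps that touch it are an at least 5.1-fold higher number from compound 1 to compound 2 (0.71 log units; beyond the scatter) and an at least 21-fold lower number from compound 2 to compound 3 (1.32 log units; beyond the scatter); the remaining step is a 4.1-fold lower number from compound 1 to compound 3 (0.61 log units; beyond the scatter), which does not involve compound 2. Compound 4 `O=C1N/C(=N\Cc2ccc(F)cc2)S/C1=C1/CCNC(=O)c2[nH]ccc21` differs from compound 2 by fluoro in place of chloro on an aromatic carbon. Within the data shown here, no measured step exchanges one halogen for another, so the size of this step can only be judged roughly: the two steps involving compound 2 both leave the chloro compound beyond the others, and a fluoro compound is expected to sit somewhere between that limit and the weaker of the two numbered values. Compound 4 is therefore expected to give 60000 nM, within a range of 15000 nM to 200000 nM, which corresponds to an expected step of an at least 1.6-fold lower number from compound 2 to compound 4 (0.22 log units; that floor lies within the scatter).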

Compound 4, half-maximal inhibitory concentration: 16900 nM
Compound 4: the middle estimate sits 3.6-fold (0.55 log units) above what was measured; low and high end bracket the measured number.
By their numbers in this assay, from the lowest: compound 3; then compounds 4 and 1 (each within the scatter of the next). At a limit, above all of these: compound 2.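

In this assay, fluoro in place of chloro gives an at least 5.9-fold lower number from compound 2 to compound 4 (0.77 log units; beyond the scatter), so carrying a halogen on this aromatic carbon does not in itself put a compound out of measurable range. The value of compound 2 remains a limit and not a number, so the true size of this step stays unknown: the limit of > 100000 nM in this assay, at which 1 of the 4 values shown sits.

Fluoro cannot be told apart from methoxy, with a 1.1-fold lower number from compound 1 to compound 4 (0.06 log units; within the scatter), whereas methyl remains ahead of fluoro, with a 3.6-fold higher number from compound 3 to compound 4 (0.55 log units; beyond the scatter), which places the fluoro compound level with the methoxy compound and behind the methyl compound at this position.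

The compounds shown leave open whether a bromo group would follow chloro or fluoro here, and whether an ethyl group would keep or extend what methyl gives. They also leave open why two halogens on the same carbon part so widely.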